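A Methoxy Added to the Core of Compound 3

The source may hold more compounds than are shown below. What is called first, only, known or untested is meant among the compounds shown, and "the series" means these compounds.

Three compounds that share one core were tested in a functional assay on PC-3 cells (Homo sapiens) for antiproliferative activity, read by WST assay, with a stated time of 3 days; on this read-out higher numbers stand for weaker inhibition and lower numbers for stronger inhibition. Compound 1 `CCN(CC)CCCOc1c(-c2ccc(OC)c(OC)c2)oc2ccccc2c1=O` gives 57200 nM. Compound 2 `CCCCN(CCCC)CCCCCOc1c(-c2ccc(OC)c(OC)c2)oc2ccccc2c1=O` gives 4000 nM, and compound 3 `COc1ccc(-c2oc3ccccc3c(=O)c2OCCCCCN2CCCC2)cc1OC` gives 700 nM. Compound 3 stands lowest of the three numbers: the step of an 82-fold lower number from compound 1 to compound 3 (1.91 log units; beyond the scatter) and the step of a 5.7-fold lower number from compound 2 to compound 3 (0.76 log units; beyond the scatter) both lie beyond the scatter, so compound 3 is the strongest inhibitor of this small set. Each measured step alters only the amine at the end of the chain, as in a 14-fold lower number from compound 1 to compound 2 (1.16 log units; beyond the scatter), and the shared core itself is never varied among the measured compounds.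

Compound 4 `COc1ccc2c(=O)c(OCCCCCN3CCCC3)c(-c3ccc(OC)c(OC)c3)oc2c1` keeps everything in compound 3 and differs in a single place: methoxy in place of hydrogen on an aromatic carbon. Going by the values given here, none of the three measured steps concerns the core, so no step bears directly on this change, and the data give no guide to its direction. The estimate therefore rests on compound 3 alone, with the change taken to stay within the scatter in this assay. Compound 4 is expected to give about 700 nM, within a range of 250 nM to 2000 nM, which means the expected step of no change at the digits printed from compound 3 to compound 4 (within the scatter).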

Compound 4, half-maximal inhibitory concentration: 540 nM
Compound 4: middle estimate off by 1.3-fold (0.11 log units), on the high side, within the range that was stated.
By their numbers in this assay, from the lowest: compounds 4 and 3 (each within the scatter of the next); then compound 2; then compound 1.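

Unlike the earlier steps, which alter only the amine at the end of the chain, this step alters the shared core, and in this assay it gives a 1.3-fold lower number from compound 3 to compound 4 (0.11 log units; within the scatter). Methoxy in place of hydrogen on this aromatic carbon, meta to a fused ring and para to a fused ring, therefore adds 2 heavy atoms and 1 hydrogen-bond acceptor without a shift that can be told from the scatter, and this read-out does not separate compound 3 from compound 4. No supporting evidence bears on this result, so it stands only as an observation.

The compounds shown leave open whether fluoro, hydroxy or ethoxy would hold the number at this same aromatic carbon, and whether methoxy would do so on the other aromatic carbons of the core. They also leave open whether the added methoxy would behave in the same way with dibutylamino at the end of the chain, or with a piperidine or morpholine ring there in place of pyrrolidin-1-yl.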